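Thiazolyl in place of hydroxyphenyl on the sulfonyl sulfur

The compounds below may be only part of what the source reports. "The series", "measured", "known", "first", "only" and "open" are said of these compounds alone.

Compound 1 `CC(O)(C(=O)Nc1ccc(S(=O)(=O)c2cccc(O)c2)cc1)C(F)(F)F`: 18000 nM
Compound 2 `COc1cc(NC(=O)C(C)(O)C(F)(F)F)ccc1S(=O)(=O)c1ccccc1`: 5900 nM
Compound 3 `CC(O)(C(=O)Nc1ccc(S(=O)(=O)c2ccccc2)c(Cl)c1)C(F)(F)F`: 2200 nM

Of the compounds shown here, three have been measured in a functional assay (Cavia porcellus) with sulfonylurea receptors; K-ATP channels (Homo sapiens) as the target; on this read-out higher numbers stand for weaker inhibition and lower numbers for stronger inhibition. Compound 1 stands highest of the three; compound 2 lies nearest and compound 3 furthest, and both of those differ from compound 1 in more than one place, so only their values speak. For the measured compounds named here, the one single-point step, a 2.7-fold lower number from compound 2 to compound 3 (0.43 log units; beyond the scatter), concerns the core and not the sulfonyl sulfur. Compound 4 `CC(O)(C(=O)Nc1ccc(S(=O)(=O)c2nccs2)cc1)C(F)(F)F` arises from compound 1 through (1,3-thiazol-2-yl in place of 3-hydroxyphenyl on a sulfonyl sulfur). Going by the values given here, no measured step bears on this change, so the direction is open; compound 4 is expected to move by a 1.5-fold lower number from compound 1 to compound 4 (0.18 log units; within the scatter), a step within the scatter. Compound 4 is therefore estimated at 12000 nM, in the range 3000 nM to 40000 nM.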

Compound 4, half-maximal inhibitory concentration: 1400 nM
Compound 4: the middle estimate sits 8.6-fold (0.93 log units) above what was measured; measured number below the stated range.
By their numbers in this assay, from the lowest: compounds 4 and 3 (each within the scatter of the next); then compound 2; then compound 1.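

At the sulfonyl sulfur, the first change read at this place in this assay proves large: 1,3-thiazol-2-yl in place of 3-hydroxyphenyl gives a 13-fold lower number from compound 1 to compound 4 (1.11 log units; beyond the scatter) on the shared core. This single step replaces a six-membered aromatic ring of carbon only with a five-membered aromatic ring with 2 hetero atoms, and it also removes the hydrogen-bond donor, so these differences cannot be separated. No evidence here accounts for the step.

As far as these compounds go, it remains open whether the loss of the hydroxyl or the entry of the thiazolyl ring drives the step. From the compounds shown here alone, how an unsubstituted phenyl or a pyridyl ring would read at this place on the core of compound 1 also remains open.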